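Methyl on a Ring Nitrogen: From Compound 2 to Compound 4

The source may hold more compounds than are shown below. What is called first, only, known or untested is meant among the compounds shown, and "the series" means these compounds.

Three compounds sharing one core were tested in an assay on isolated protein for inhibition of Leucine-rich repeat serine/threonine-protein kinase 2 variant G2019S (Homo sapiens), read by TR-FRET and LanthaScreen, with stated times of 50 min and 30 min, in the presence of a further agent that is not named here; on this read-out higher numbers stand for weaker inhibition and lower numbers for stronger inhibition. Compound 1 `Cn1c(N2CCCC2)c(C#N)c2c(N)ncnc21` gives 1910 nM. Compound 2 `C[C@@H]1CCCN1c1c(C#N)c2c(N)nc(Nc3cn[nH]c3)nc2n1C` gives 6 nM, the lowest of the three numbers, far below compound 1 and within the scatter of compound 3 `Cc1c(Nc2nc(N)c3c(C#N)c(N4CCC[C@H]4C)n(C)c3n2)cnn1CC1(O)COC1`, which gives 10 nM. Compound 4 `C[C@@H]1CCCN1c1c(C#N)c2c(N)nc(Nc3cnn(C)c3)nc2n1C` has not yet been measured in this assay. It differs from compound 2 in one place: methyl in place of hydrogen on an aromatic nitrogen. Going by the values given here, no measured pair shows this change directly. Because compound 3 gives 10 nM although it is more heavily substituted than compound 2, the core appears to tolerate added groups, so the step of a 1.3-fold higher number from compound 2 to compound 4 (0.12 log units; within the scatter) is expected to be small and within the scatter. Compound 4 is estimated at 8 nM, with a likely range from 3 nM to 25 nM.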

Compound 4, half-maximal inhibitory concentration: 5 nM
Compound 4: middle estimate off by 1.6-fold (0.20 log units), on the high side, and the stated range covers the measured number.
By their numbers in this assay, from the lowest: compounds 4, 2 and 3 (each within the scatter of the next); then compound 1.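

Putting methyl in place of the hydrogen on this aromatic nitrogen gives a 1.2-fold lower number from compound 2 to compound 4 (0.08 log units; within the scatter) and so leaves compound 4 indistinguishable from compound 2. This direct comparison shows that, on this core, the hydrogen on that nitrogen is not needed to keep the number at the level of compound 2. No measurement shown here offers an explanation for this result. From the compounds shown here alone, what remains open is whether this nitrogen would also accept something larger than methyl, such as an ethyl group or a longer chain ending in an amine or a carboxylic acid.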